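Methoxy on the acetamide of compound 2

This account rests on a few compounds, and the source may have more. Where it says the series, first, only, none or still open, it means among the compounds named here.

Compound 2 `CC(=O)Nc1ccc2c(cnn2CC(=O)COc2ccc(Oc3ccccc3)cc2)c1` carries an acetamido group on its aromatic core, where compound 1 `O=C(COc1ccc(Oc2ccccc2)cc1)Cn1ncc2cc(C(=O)O)ccc21` carries a carboxy group. In an assay on microsomes from brain for inhibition of Fatty-acid amide hydrolase 1 (Rattus norvegicus), read by fluorescence and HPLC, with a stated time of 45 min (a higher number here means a weaker inhibitor, a lower number a stronger inhibitor), compound 1 gives 55 nM, while compound 2 gives 3900 nM, the higher of the two numbers shown; the change a 71-fold higher number from compound 1 to compound 2 (1.85 log units; beyond the scatter) is the only measured step in this set. Compound 3 `COCC(=O)Nc1ccc2c(cnn2CC(=O)COc2ccc(Oc3ccccc3)cc2)c1` differs from compound 2 by methoxy in place of hydrogen on a saturated chain carbon bound to a carbonyl carbon. For the measured compounds named here, no measured step concerns this change: the single known step swaps the whole acetamido group for carboxy, and says nothing about substitution on the acetamide methyl. Going by the values given here, with no step bearing on it, compound 3 is expected to stay close to compound 2, with a step of a 1.1-fold lower number from compound 2 to compound 3 (0.05 log units; within the scatter) in this assay that is not expected to go beyond the scatter. The estimate for compound 3 in this assay is therefore 3500 nM, between 1200 nM and 10000 nM.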

Compound 3, half-maximal inhibitory concentration: 6300 nM
Estimate against measurement, compound 3: 1.8-fold (0.26 log units) below; measured number inside the range.
By their numbers in this assay, from the lowest: compound 1; then compounds 2 and 3 (each within the scatter of the next).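

In this assay, methoxy on the saturated chain carbon bound to the carbonyl carbon gives a 1.6-fold higher number from compound 2 to compound 3 (0.21 log units; within the scatter), so compound 2 and compound 3 cannot be told apart at this position. The replacement of carboxy on the aromatic carbon by ((methoxymethyl)carbonyl)amino gives a 110-fold higher number from compound 1 to compound 3 (2.06 log units; beyond the scatter), a large step like a 71-fold higher number from compound 1 to compound 2 (1.85 log units; beyond the scatter), so the large gap to compound 1 holds for both of these amides. Nothing at hand accounts for either step.

As far as these compounds go, it remains open whether a longer chain such as ethoxy, or an amine such as dimethylamino, on the same carbon would also stay within the scatter of compound 2. From the compounds shown here alone, it is equally open whether a carboxylic acid placed at the end of this chain would bring the number back towards that of compound 1.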